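Chloro in Place of Piperidin-1-yl on the Amide Chain

The source may hold more compounds than are shown below. What is called first, only, known or untested is meant among the compounds shown, and "the series" means these compounds.

Compound 1 `Cc1ccc(-c2nc3cc(NC(=O)CCN4CCCCC4)ccc3[nH]2)cc1` gives 11900 nM
Compound 2 `CCN1CCN(CCC(=O)Nc2ccc3[nH]c(-c4cccn4C)nc3c2)CC1` gives > 50000 nM (a limit of the assay)

For the measured compounds named here, in a functional assay on HepG2 cells (Homo sapiens) for cytotoxicity, read by MTT assay, with a stated time of 72 h (on this read-out higher numbers stand for weaker inhibition and lower numbers for stronger inhibition), compound 1 gives 11900 nM as the only exact number so far. Compound 3 `Cc1ccc(-c2nc3cc(NC(=O)CCCl)ccc3[nH]2)cc1` keeps the core of compound 1. The change chloro in place of piperidin-1-yl on a saturated chain carbon, two bonds along the chain from a carbonyl carbon puts chloro in place of piperidin-1-yl on a saturated chain carbon, two bonds along the chain from a carbonyl carbon. Going by the values given here, no measured step shows what this swap does, so in this assay little beyond the scatter is expected, with a slight lean towards weaker inhibition. The expected step is a 1.5-fold higher number from compound 1 to compound 3 (0.18 log units; within the scatter) and it remains uncertain. Compound 3 is estimated at 18000 nM (range 5000 nM to 50000 nM).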

Compound 3, half-maximal inhibitory concentration: > 50000 nM
Compound 3 ended at the assay's limit; the forecaster's own chance of this, stated with the estimate: 15%; middle value at least 2.7-fold (0.44 log units) away from the limit.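

In this assay, for the compounds shown here, chloro in place of piperidin-1-yl gives an at least 4.2-fold higher number from compound 1 to compound 3 (0.62 log units; beyond the scatter) at this place on the chain, the first measured step here. The group at the end of the amide chain therefore matters: with chloro there, the inhibition seen with piperidin-1-yl is lost within the range this assay can read. Compound 3 stands at a limit of the assay, so the full size of the step cannot be read: the limit of > 50000 nM in this assay, at which 2 of the 3 values shown sit.

From the compounds shown here alone, it remains open whether a smaller amine such as dimethylamino, or morpholin-4-yl, would keep the number of compound 1 at this place. Going by these compounds, it is also open how a longer chain carrying piperidin-1-yl would read.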